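Butoxy to Methoxymethoxy: What to Expect in Cytotoxicity

The source may hold more compounds than are shown below. What is called first, only, known or untested is meant among the compounds shown, and "the series" means these compounds.

Compound 1 `Cn1cc(/C=N/NC(N)=S)c2ccccc21` in a toxicity assay on MRC5 cells (Homo sapiens) for cytotoxicity, read by MTT assay, with a stated time of 72 h (on this read-out higher numbers stand for an effect only at larger amounts of compound and lower numbers for an effect already at smaller amounts), gives > 200000 nM, which is a limit of the assay rather than a number.
Compound 2 `NC(=S)N/N=C/c1cn(CCCc2ccccc2)c2ccccc12` gives > 200000 nM in this assay, again a limit.
Compound 3 `CCCCOc1c(/C=N/NC(N)=S)ccc2ccccc12` gives 86000 nM in this assay.

Compound 3 is thus the only one of the three with a real number; the other two sit at the limit (the limit of > 200000 nM in this assay, at which 2 of the 3 values shown sit). Among the compounds with values here, the single step that joins two measured compounds, a step that the two limits leave unreadable from compound 1 to compound 2, cannot be sized, as both of its ends are limits.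

Compound 4 `COCOc1c(/C=N/NC(N)=S)ccc2ccccc12` differs from compound 3 in one place: methoxy in place of propyl on a saturated chain carbon bound to an oxygen on an aromatic ring. Within the data shown here, no measured step touches this place, and the only measured step is itself unreadable, so the numbers give no guidance in either direction. The plain expectation is therefore that compound 4 stays close to compound 3, with the step of no change at the digits printed from compound 3 to compound 4 (within the scatter) expected to lie within the usual scatter. Compound 4 is estimated at 86000 nM, within the range 30000 nM to 250000 nM.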

Compound 4, half-maximal effective concentration: 119000 nM
For compound 4 the middle estimate is 1.4-fold (0.14 log units) below the measured one, and the stated range covers the measured number.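

In this assay the pair shows a 1.4-fold higher number from compound 3 to compound 4 (0.14 log units; within the scatter) when methoxy takes the place of propyl on a saturated chain carbon bound to an oxygen on an aromatic ring. Within the data shown here, this is the first step here with a real number at both ends, and it shows that this read-out does not separate butoxy from methoxymethoxy, even though the entering methoxy carries an oxygen and a hydrogen-bond acceptor that propyl lacks. Among these compounds, compound 1 and compound 2 each stand at a limit, so the one earlier step cannot be read: the limit of > 200000 nM in this assay, at which 2 of the 4 values shown sit.

On these data alone, whether a longer chain, an amine or a carboxylic acid at this place would also stay this close to compound 3 remains open. A single readable step cannot show how far this holds for other groups or on other cores.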